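A Pyridine for the Nitrophenyl End of a Cinnamanilide

The source may hold more compounds than are shown below. What is called first, only, known or untested is meant among the compounds shown, and "the series" means these compounds.

Of the compounds shown here, two have numbers so far in a functional assay on HT-29 cells (Homo sapiens) for inhibition, read by MTT assay, with a stated time of 48 h; on this read-out higher numbers stand for weaker inhibition and lower numbers for stronger inhibition. Compound 1 `COc1cc(/C=C/c2ccc(NC(=O)/C=C/c3cc(OC)c(OC)c(OC)c3)cc2)cc(OC)c1` carries a trimethoxyphenyl group on the amide side of the shared core; in this assay compound 1 gives 1820 nM. Compound 2 `COc1cc(/C=C/c2ccc(NC(=O)/C=C/c3ccc([N+](=O)[O-])cc3)cc2)cc(OC)c1` carries a 4-nitrophenyl group in that place instead, and in this assay compound 2 gives 10700 nM, the highest of the two numbers, with compound 1 the nearest and its number lower by a gap that lies beyond the usual scatter.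

Compound 3 `COc1cc(/C=C/c2ccc(NC(=O)/C=C/c3ccccn3)cc2)cc(OC)c1` has not yet been measured. It differs from compound 2 in one place: pyridin-2-yl in place of 4-nitrophenyl on a double-bonded chain carbon bound to a double-bonded chain carbon

Going by the values given here, with only two numbers in hand and no measured step of this kind, the account can only offer an expectation. Compound 3 is expected to come in at 6000 nM, with a range from 2000 nM to 20000 nM. Among the compounds with values here, this estimate corresponds to a step of a 1.8-fold lower number from compound 2 to compound 3 (0.25 log units; within the scatter), expected to fall toward lower numbers but probably not beyond the scatter, since the number of compound 1 at 1820 nM marks the only lower value seen so far in this assay.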

Compound 3, half-maximal inhibitory concentration: 6120 nM
Compound 3: middle estimate off by 1.0-fold (0.01 log units), on the low side; the range from low to high includes it.
By their numbers in this assay, from the lowest: compound 1; then compounds 3 and 2 (each within the scatter of the next).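

In this assay, going by these compounds alone, pyridin-2-yl in place of 4-nitrophenyl on a double-bonded chain carbon bound to a double-bonded chain carbon gives a 1.7-fold lower number from compound 2 to compound 3 (0.24 log units; within the scatter) and so provides the first step that can be read at this position. The change removes a carbon-only ring bearing a nitro group, 9 heavy atoms in all, and brings in a ring of 6 heavy atoms with 1 hetero atom, yet the two numbers stay within the usual scatter, so this assay does not separate the two groups. Nothing at hand shows why the numbers of the two compounds lie so close.

The step leaves open what each part of the exchange contributes, since the loss of the nitro group and the entry of the ring nitrogen happen together in one change. An unsubstituted phenyl, pyridin-3-yl, pyridin-4-yl or 4-aminophenyl in the same place would be needed to pull these apart, and to show whether any such group can reach the number of compound 1 at 1820 nM in this assay without its trimethoxyphenyl group.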